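Acyl ester series: from compound 2 to compound 4

The compounds below may be only part of what the source reports. "The series", "measured", "known", "first", "only" and "open" are said of these compounds alone.

compound 1 `CCC(=O)Oc1c(C(C)C)cc2c3c1OC(=O)[C@@]31CCCC(C)(C)[C@@H]1CC2`: 113000 nM
compound 2 `CCCCCCCCCCCC(=O)Oc1c(C(C)C)cc2c3c1OC(=O)[C@@]31CCCC(C)(C)[C@@H]1CC2`: 413000 nM
compound 3 `CCCCCCCC/C=C/CCCCCCCC(=O)Oc1c(C(C)C)cc2c3c1OC(=O)[C@@]31CCCC(C)(C)[C@@H]1CC2`: 822000 nM

In an ADME assay on AGS cells (Homo sapiens) for cytotoxicity, read by neutral red uptake, with a stated time of 24 h (a higher number here means a weaker inhibitor, a lower number a stronger inhibitor), compound 2 stands second highest of the three numbers. Compound 4 `CC(C)c1cc2c3c(c1OC(=O)CCCc1c[nH]c4ccccc14)OC(=O)[C@@]31CCCC(C)(C)[C@@H]1CC2` differs from compound 2 by 1H-indol-3-yl in place of octyl on a saturated chain carbon, three bonds along the chain from a carbonyl carbon. For the measured compounds named here, two measured steps bear on this: a 3.7-fold higher number from compound 1 to compound 2 (0.56 log units; beyond the scatter), and a 2.0-fold higher number from compound 2 to compound 3 (0.30 log units; within the scatter). Going by the values given here, both involve plain carbon chains, and no measured compound carries an indole, so the guidance is limited. Going by a 3.7-fold higher number from compound 1 to compound 2 (0.56 log units; beyond the scatter), a lower number is expected, by a step of similar size or smaller. The estimated change is a 2.1-fold lower number from compound 2 to compound 4 (0.31 log units; beyond the scatter). For compound 4 the expected value is 200000 nM, with an estimated range of 80000 nM to 500000 nM.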

Compound 4, half-maximal inhibitory concentration: 46800 nM
Estimate against measurement, compound 4: 4.3-fold (0.63 log units) above, and the stated range ends above it.
By their numbers in this assay, from the lowest: compound 4; then compound 1; then compounds 2 and 3 (each within the scatter of the next).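

In this assay, replacing octyl with 1H-indol-3-yl at this chain position reverses the rise seen along the plain carbon chains, giving an 8.8-fold lower number from compound 2 to compound 4 (0.95 log units; beyond the scatter). The indole also takes the number below that of the short-chain ester, with a 2.4-fold lower number from compound 1 to compound 4 (0.38 log units; beyond the scatter), so compound 4 goes against the rise with added chain carbons seen from compound 1 to compound 2. No evidence on hand accounts for this shift.

As far as these compounds go, whether this depends on the indole itself or on any aromatic ring at the chain end remains open; a phenyl group there would test this. Also open, from the compounds shown here alone, is how the number responds to a shorter or longer link to the 1H-indol-3-yl, or to a terminal amine or carboxylic acid.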